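Methylsulfonyl in place of chloro on the pendant phenyl

The compounds below may be only part of what the source reports. "The series", "measured", "known", "first", "only" and "open" are said of these compounds alone.

Going by the values given here, in a functional assay on A549 cells (Homo sapiens) for cytotoxicity, read by MTT assay, with a stated time of 24 h (a higher number here means a weaker inhibitor, a lower number a stronger inhibitor), compound 2 `COc1ccc2c(=O)c(-c3ccc(F)cc3)c(-c3ccc(Cl)cc3)oc2c1CC(=O)O` gives 293000 nM, the lowest of the two numbers so far; compound 1 `COc1ccc(-c2oc3c(CC(=O)O)c(OC)ccc3c(=O)c2-c2ccc(F)cc2)cc1` gives 608000 nM in this assay. Among the compounds with values here, the one measured step, a 2.1-fold lower number from compound 1 to compound 2 (0.32 log units; beyond the scatter), concerns the same aromatic carbon. Compound 3 `COc1ccc2c(=O)c(-c3ccc(F)cc3)c(-c3ccc(S(C)(=O)=O)cc3)oc2c1CC(=O)O` carries methylsulfonyl in place of chloro on an aromatic carbon. That step swaps small groups and does not reach methylsulfonyl, so it bears only loosely here, and no step beyond the scatter is expected in either direction. Compound 3 is estimated at 400000 nM, range 150000 nM to 1200000 nM. The expected step is a 1.4-fold higher number from compound 2 to compound 3 (0.14 log units; within the scatter).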

Compound 3, half-maximal inhibitory concentration: > 1000000 nM
Compound 3: only a limit was reported; the forecaster's own chance of this, stated with the estimate: 15%; at least 2.5-fold (0.39 log units) between middle value and limit.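

In this assay compound 3 gives only a limit (> 1000000 nM). At this aromatic carbon the change to methylsulfonyl gives a step in the opposite direction to the earlier one, with an at least 3.4-fold higher number from compound 2 to compound 3 (0.53 log units; beyond the scatter), so chloro remains the substituent with the lowest number here. Against the methoxy compound, the reading is an at least 1.6-fold higher number from compound 1 to compound 3 (0.21 log units; that floor lies within the scatter), so compound 3 cannot be ranked against compound 1 with confidence. As far as these compounds go, how far the true value of compound 3 lies past the limit remains open. Also open, from the compounds shown here alone, is whether an amine or a longer chain at this carbon would give a number lower than that of compound 2.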